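The compounds below may be only part of what the source reports. "The series", "measured", "known", "first", "only" and "open" are said of these compounds alone.

Measured so far:
compound 1, `O=C(Nc1ccc(I)cc1)c1cncc(N2CC3CC(C2)N3)c1`: 103 nM in an assay on cells for displacement of a labelled ligand from Neuronal acetylcholine receptor; alpha3/beta4 (Homo sapiens); on this read-out higher numbers stand for weaker inhibition and lower numbers for stronger inhibition
compound 2, `COc1cc(NC(=O)c2cncc(N3CC4CC(C3)N4)c2)cc(OC)c1`: 2000 nM in this assay

Two compounds share one core and differ only in the aromatic ring attached through the amide. In this assay compound 1 gives 103 nM, the lower of the two numbers, and compound 2 gives 2000 nM, a gap that lies beyond the usual scatter of repeated measurements. Nothing more than these two numbers is known, so the weight of a single substituent on that ring has not been measured directly.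

Compound 3, `O=C(Nc1ccc(F)cc1)c1cncc(N2CC3CC(C2)N3)c1`, is not yet measured. It differs from compound 1 in one place: fluoro in place of iodo on an aromatic carbon. Going by the values given here, no measured pair shows this exchange, so any expectation rests on the two numbers above. Since only compound 1 carries a single halogen on that ring and its value 103 nM is the lowest seen, a modest move toward a higher number is expected, but not one beyond the span between compound 1 and compound 2. The expected step is a 3.4-fold higher number from compound 1 to compound 3 (0.53 log units; beyond the scatter). For compound 3 the estimate in this assay is 350 nM, within 120 nM to 1200 nM.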

Compound 3, inhibition constant: 81 nM
Beside the measured number, compound 3's estimate is 4.3-fold (0.64 log units) above it; the measured number lies below the stated range.
By their numbers in this assay, from the lowest: compounds 3 and 1 (each within the scatter of the next); then compound 2.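

In this assay, the change from 4-iodophenyl to 4-fluorophenyl comes with a 1.3-fold lower number from compound 1 to compound 3 (0.10 log units; within the scatter), so on this read-out the two halogens cannot be told apart. Going by these compounds alone, this is the first direct look at a single exchange on this ring, and it shows that the low number of compound 1 does not depend on iodo specifically: at this place, para to a large group, fluoro serves equally well, even though the two atoms are far apart in size within the halogen family. Nothing in hand explains why the two groups give such similar numbers.

From the compounds shown here alone, what remains open is whether this tolerance reaches beyond halogens, since an amine, a carboxylic acid or a longer chain on the same aromatic carbon could give a very different number. Going by these compounds, a plain hydrogen at this carbon would also show whether any group is needed there at all, and it is still unknown whether the two halogens would match in the same way on other carbons of the ring.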